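Thiophene for phenyl on a sulfamoyl core

A few compounds are considered here, and "the series" means these few. Any claim that something is new, unique, unknown or untested is made for them only; others in the source may bear on it.

The measured compounds:
compound 1, `CC(C)Nc1nc(Nc2ccc(N3CCN(C)CC3)cc2)ncc1/N=C/c1ccccc1`, gives 12100 nM;
compound 2, `CC(C)Nc1nc(Nc2ccc(N3CCN(C)CC3)cc2)ncc1/N=C/c1cccs1`, gives > 100000 nM;
compound 3, `CC(C)Nc1nc(Nc2ccc(S(N)(=O)=O)cc2)ncc1/N=C/c1ccccc1`, gives 98200 nM.

All three were tested in a functional assay on HT-29 cells (Homo sapiens) for antiproliferative activity, read by MTT assay; a lower number here means a stronger inhibitor, a higher number a weaker inhibitor. Compound 1 is the reference; compound 2 carries thiophen-2-yl in place of phenyl on a carbon with a double bond to nitrogen, and the step of an at least 8.2-fold higher number from compound 1 to compound 2 (0.91 log units; beyond the scatter) is a loss of potency. The value of compound 2 is a limit of the assay and not a number, as the limit of > 100000 nM in this assay, at which 1 of the 3 values shown sits, shows, so the true size of that step is open. Compound 3 differs from compound 1 in its core, with sulfamoyl in place of 4-methylpiperazin-1-yl on an aromatic carbon, and the step of an 8.1-fold higher number from compound 1 to compound 3 (0.91 log units; beyond the scatter) is also a loss. Compound 3 thus stands as the weakest of the two compounds with numbers.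

The unmeasured compound 4, `CC(C)Nc1nc(Nc2ccc(S(N)(=O)=O)cc2)ncc1/N=C/c1cccs1`, is compound 3 with thiophen-2-yl in place of phenyl on a carbon with a double bond to nitrogen. This is the same change as from compound 1 to compound 2; the place is described in the same words in both cases, and it occurs twice among the compounds shown. Within the data shown here, the step of a 5.1-fold higher number from compound 3 to compound 4 (0.71 log units; beyond the scatter) is expected to resemble an at least 8.2-fold higher number from compound 1 to compound 2 (0.91 log units; beyond the scatter), since that is the only measurement of this change; as the earlier step ran into the limit, compound 4 is expected to end at the limit as well. On that basis compound 4 is estimated at 500000 nM, with a range from 150000 nM to 2000000 nM.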

Compound 4, half-maximal inhibitory concentration: > 100000 nM
Compound 4 was reported as a limit (the forecaster's own chance of this, stated with the estimate: 85%); the middle value lies beyond the limit too.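

In this assay compound 4 gives > 100000 nM, which is a limit of the assay and not a number. Thiophen-2-yl in place of phenyl on the sulfamoyl-bearing core gives an at least 1.0-fold higher number from compound 3 to compound 4 (0.00 log units; that floor lies within the scatter), which is only a floor, and set beside the earlier step it reads: the same change on two cores in this assay, an at least 8.2-fold higher number (0.91 log units; beyond the scatter) from compound 1 to compound 2 and an at least 1.0-fold higher number (0.00 log units; that floor lies within the scatter) from compound 3 to compound 4; the limit leaves it open whether they differ. On both cores the compound with thiophen-2-yl ends at a limit, but this does not show that the change has the same size on the two cores, or that it lowers potency at all on the core of compound 3, and the step from compound 2 to compound 4 cannot be read, as both of its ends are limits: the limit of > 100000 nM in this assay, at which 2 of the 4 values shown sit.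

The compounds shown leave open how large the change from phenyl to thiophen-2-yl really is on either core. They also leave open whether furan-2-yl or pyridin-2-yl on a carbon with a double bond to nitrogen would give numbers on both cores, so that the same change could be compared as two full steps and not as two floors.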